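Nitrophenyl for difluorophenyl on the pyrazole-type core: cytotoxicity notes

A few compounds are considered here, and "the series" means these few. Any claim that something is new, unique, unknown or untested is made for them only; others in the source may bear on it.

Measured so far:
compound 1, `CN1CCN(CCCNCc2cn(-c3ccc([N+](=O)[O-])cc3)nc2-c2ccc(OC(F)(F)F)cc2)CC1`: 1600 nM
compound 2, `Cc1ccccc1-c1nn(-c2ccc(F)c(F)c2)cc1CNCCN1CCN(C)CC1`: > 20000 nM

In an ADME assay on Huh-7 cells (Homo sapiens) for cytotoxicity (on this read-out higher numbers stand for lower toxicity in this test and lower numbers for higher toxicity in this test), compound 1 gives 1600 nM. For compound 2 only a limit is known in this assay, > 20000 nM, which is a limit of the assay and not a number. For the measured compounds named here, the two compounds differ in more than one place, so the two values show only that compound 2 sits at the limit while compound 1 gives a number inside the measured range; no step between them is defined. The limit is recorded as the limit of > 20000 nM in this assay, at which 1 of the 2 values shown sits.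

Compound 3, `Cc1ccccc1-c1nn(-c2ccc([N+](=O)[O-])cc2)cc1CNCCN1CCN(C)CC1`, is not yet measured in this assay. It is derived from compound 2 by one change: 4-nitrophenyl in place of 3,4-difluorophenyl on an aromatic nitrogen. Going by the values given here, no measured step in this assay runs between compounds that differ in a single place, so the size of this step is open. Compound 1, which carries a 4-nitrophenyl group, gives a number in this assay, whereas compound 2 sits at the limit; this is the only pointer, and it is weak. The expectation is a step toward higher toxicity, an at least 2.5-fold lower number from compound 2 to compound 3 (0.39 log units; beyond the scatter), of modest size. Compound 3 is expected at 8000 nM, within 2500 nM to 25000 nM.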

Compound 3, half-maximal cytotoxic concentration: > 20000 nM
Compound 3: only a limit was reported (the forecaster's own chance of this, stated with the estimate: 40%); middle value at least 2.5-fold (0.39 log units) from the limit.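

Compound 3, like compound 2, stands only at a limit of the assay in this assay, and no step between the two can be read: the limit of > 20000 nM in this assay, at which 2 of the 3 values shown sit.

The compounds shown leave open whether 4-nitrophenyl in place of 3,4-difluorophenyl changes this read-out at all on the shared core, as compound 1 differs from both in more than one place.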